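Removing a methoxy group from a bis-indolyl quinone

The compounds below may be only part of what the source reports. "The series", "measured", "known", "first", "only" and "open" are said of these compounds alone.

Measured so far:
compound 1 `Cc1[nH]c2ccccc2c1C1=C(Cl)C(=O)C(c2c(-c3ccccc3)[nH]c3ccccc23)=C(Cl)C1=O` — 2.29 ug/mL
compound 2 `COc1ccc2[nH]c(C)c(C3=C(Cl)C(=O)C(c4c(-c5ccc(C)cc5)[nH]c5ccccc45)=C(Cl)C3=O)c2c1` — 3.11 ug/mL

Both compounds share a dichlorinated quinone core carrying two indole units. In a functional assay on MCF7 cells (Homo sapiens) for antiproliferative activity, read by CCK-8 assay, with a stated time of 48 h (on this read-out lower numbers stand for stronger inhibition and higher numbers for weaker inhibition), compound 1 gives 2.29 ug/mL, and in the same test compound 2 gives 3.11 ug/mL. Compound 2 shows the higher of the two numbers, but the gap to compound 1 is within the scatter of this kind of measurement, so the two cannot be told apart.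

Compound 3 `Cc1ccc(-c2[nH]c3ccccc3c2C2=C(Cl)C(=O)C(c3c(C)[nH]c4ccccc34)=C(Cl)C2=O)cc1` has not been measured. It differs from compound 2 in one place: hydrogen in place of methoxy on an aromatic carbon, a hydrogen in place of methoxy on an aromatic carbon. Within the data shown here, no measured pair tells how this particular change has behaved before, so there is no step to lean on. Given that both measured compounds sit close together, the expected step from compound 2 to compound 3 is a 1.2-fold lower number from compound 2 to compound 3 (0.08 log units; within the scatter), which is no more than the usual scatter in either direction. Compound 3 is therefore estimated at 2.6 ug/mL, with a plausible range from 1.3 ug/mL to 5.2 ug/mL.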

Compound 3, half-maximal inhibitory concentration: 2.8 ug/mL
Compound 3: the middle estimate sits 1.1-fold (0.03 log units) below what was measured; measured number inside the range.
By their numbers in this assay, from the lowest: compounds 1, 3 and 2 (each within the scatter of the next).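

Taking the methoxy group away, so that 5-methoxy-2-methyl-1H-indol-3-yl becomes 2-methyl-1H-indol-3-yl, can now be read as a single change in this assay and gives a 1.1-fold lower number from compound 2 to compound 3 (0.05 log units; within the scatter), so hydrogen and methoxy at this position cannot be told apart in these compounds. A second single change, methyl in place of hydrogen on an aromatic carbon, gives a 1.2-fold higher number from compound 1 to compound 3 (0.09 log units; within the scatter) and likewise shows no difference that can be separated from the scatter, so neither change has a readable effect on this pair of compounds. No measurement among the data speaks to why these values stay so close.

The compounds shown compare only hydrogen with methoxy at this position, which leaves open how an amine, a carboxylic acid or a longer chain such as ethoxy would read there. Going by these compounds, it also remains open whether the same two changes would stay within the scatter on a different core or in a different cell line.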